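Swapping naphthalenyl for cyclohexyl: a cytotoxicity guess

The source may hold more compounds than are shown below. What is called first, only, known or untested is meant among the compounds shown, and "the series" means these compounds.

Three compounds have been measured so far:

Compound 1 `COc1ccc(F)cc1CNCCCNc1ccnc2cc(C3CCCCC3)ccc12` gives 2290 nM in an ADME assay on HepG2 cells (Homo sapiens) for cytotoxicity, read by luminescence, CellTiter-Glo and ATP content, with a stated time of 72 h; a higher number here means that more compound is needed for the effect, a lower number that less compound is needed.
Compound 2 `COc1ccc(F)cc1CNCCCNc1ccnc2cc(-c3cccc4ccccc34)ccc12` gives 16000 nM in this assay.
Compound 3 `c1coc(CNCCCNc2ccnc3cc(-c4cccc5ccccc45)ccc23)c1` gives 5600 nM in this assay.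

Compound 4 `c1coc(CNCCCNc2ccnc3cc(C4CCCCC4)ccc23)c1` has not yet been measured. It differs from compound 3 by one change, (cyclohexyl in place of naphthalen-1-yl on an aromatic carbon). The very same change, on the very same place, has already been made once: cyclohexyl in place of naphthalen-1-yl on an aromatic carbon. That earlier step gave a 7.0-fold lower number from compound 2 to compound 1 (0.84 log units; beyond the scatter).

The two pairs do not share a core. Compound 3 differs from compound 2 by furan-2-yl in place of 5-fluoro-2-methoxyphenyl on a saturated chain carbon bound to an amine nitrogen, and that change on its own gave a 2.9-fold lower number from compound 2 to compound 3 (0.46 log units; beyond the scatter). So compound 3 already starts from a lower number than compound 2.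

If the change behaves on the core of compound 3 as it did on the core of compound 2, a step of about a 6.2-fold lower number from compound 3 to compound 4 (0.79 log units; beyond the scatter) is expected in this assay, resting on a 7.0-fold lower number from compound 2 to compound 1 (0.84 log units; beyond the scatter). On that basis compound 4 is estimated at 900 nM, with a likely range from 300 nM to 2700 nM. The measurement will show whether the step carries over.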

Compound 4, half-maximal effective concentration: 4760 nM
For compound 4 the middle estimate is 5.3-fold (0.72 log units) below the measured one, outside the stated range (above it).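

In this assay, the swap of naphthalen-1-yl for cyclohexyl did not carry over from one core to the other, as the new step is a 1.2-fold lower number from compound 3 to compound 4 (0.07 log units; within the scatter), and the earlier step has no match here: the same change on two cores in this assay, a 7.0-fold lower number (0.84 log units; beyond the scatter) from compound 2 to compound 1 and a 1.2-fold lower number (0.07 log units; within the scatter) from compound 3 to compound 4, 5.9-fold (0.77 log units) apart, beyond the scatter of two such steps. The other change in these four compounds, furan-2-yl in place of 5-fluoro-2-methoxyphenyl, also depends on its surroundings, because with cyclohexyl on the aromatic carbon it gives a 2.1-fold higher number from compound 1 to compound 4 (0.32 log units; beyond the scatter), the opposite direction from its step with naphthalen-1-yl: the same change on two cores in this assay, a 2.9-fold lower number (0.46 log units; beyond the scatter) from compound 2 to compound 3 and a 2.1-fold higher number (0.32 log units; beyond the scatter) from compound 1 to compound 4, 5.9-fold (0.77 log units) apart, beyond the scatter of two such steps. So, in this set, the effect of each change depends on the other, but the four compounds do not show why, and they cannot predict the step on any further core.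

As far as these compounds go, it remains open whether this dependence would also appear with another group on the aromatic carbon, such as tert-butyl in place of cyclohexyl. The same question applies to another group on the chain, such as thiophen-2-yl in place of furan-2-yl.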